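Pyridin-3-yl for thiophen-2-yl on a methoxy-anilino core

The compounds below may be only part of what the source reports. "The series", "measured", "known", "first", "only" and "open" are said of these compounds alone.

Compound 2 `c1csc(-c2ccnc(Nc3ccc(-n4ccnc4)cc3)n2)c1` gives 4300 nM in a functional assay for inhibition, with Homo sapiens as the target; on this read-out lower numbers stand for stronger inhibition and higher numbers for weaker inhibition. Compound 1 `c1cncc(-c2ccnc(Nc3ccc(-n4ccnc4)cc3)n2)c1` differs from it by pyridin-3-yl in place of thiophen-2-yl on an aromatic carbon, and in this assay compound 1 gives 1300 nM, so that a 3.3-fold lower number from compound 2 to compound 1 (0.52 log units; beyond the scatter). Compound 3 `COc1ccc(Nc2nccc(-c3cccs3)n2)cc1` has a different core, differing from compound 2 by methoxy in place of 1H-imidazol-1-yl on an aromatic carbon; in this assay compound 3 gives 3900 nM. Compound 4 `COc1ccc(Nc2nccc(-c3cccnc3)n2)cc1`, not yet measured, differs from compound 3 by pyridin-3-yl in place of thiophen-2-yl on an aromatic carbon. This is the same kind of change as that from compound 2 to compound 1, though the surroundings read slightly differently: meta to a large group in compound 1, meta to a group of 9 heavy atoms in compound 4. For compound 4 the expected step is a 3.3-fold lower number from compound 3 to compound 4 (0.51 log units; beyond the scatter). That expectation rests on the earlier step of a 3.3-fold lower number from compound 2 to compound 1 (0.52 log units; beyond the scatter) and on the two cores lying close together, since a 1.1-fold lower number from compound 2 to compound 3 (0.04 log units; within the scatter). Compound 4 is therefore estimated at 1200 nM, expected between 500 nM and 3000 nM.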

Compound 4, half-maximal inhibitory concentration: 1700 nM
The estimate for compound 4 lay 1.4-fold (0.15 log units) below the measured number; low and high end bracket the measured number.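

In this assay, pyridin-3-yl in place of thiophen-2-yl again gives a lower number, with a 2.3-fold lower number from compound 3 to compound 4 (0.36 log units; beyond the scatter), and the step agrees from one core to the other: the same change on two cores in this assay, a 3.3-fold lower number (0.52 log units; beyond the scatter) from compound 2 to compound 1 and a 2.3-fold lower number (0.36 log units; beyond the scatter) from compound 3 to compound 4, 1.4-fold (0.16 log units) apart, within the scatter of two such steps. Methoxy in place of 1H-imidazol-1-yl also stays within the scatter with pyridin-3-yl present, with a 1.3-fold higher number from compound 1 to compound 4 (0.12 log units; within the scatter), so the two changes read as independent of each other across these four compounds: the same change on two cores in this assay, a 1.1-fold lower number (0.04 log units; within the scatter) from compound 2 to compound 3 and a 1.3-fold higher number (0.12 log units; within the scatter) from compound 1 to compound 4, 1.4-fold (0.16 log units) apart, within the scatter of two such steps. This rests on a single pair of cores and does not show that the step would carry to any other core, nor why the number falls.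

The compounds shown leave open whether phenyl or pyridin-4-yl in this place would follow the same step. They also leave open whether an amine or a carboxylic acid in place of methoxy would preserve it.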